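Inverting both stereocentres of compound 1

The compounds below may be only part of what the source reports. "The series", "measured", "known", "first", "only" and "open" are said of these compounds alone.

Compound 1 `CC(C)=CCCC1=CC[C@@H](C(=O)Nc2ccc(C(=O)O)cc2)[C@H](c2ccccc2)C1` is the weaker of the two compounds with a number in an assay on isolated protein for inhibition of Apoptosis regulator Bcl-2 (Homo sapiens), read by fluorescence polarization, with stated times of 5 min and 10 min; on this read-out lower numbers stand for stronger inhibition and higher numbers for weaker inhibition: compound 1 gives 2200 nM. Compound 2 `CC(C)=CCCC1=CC[C@@H](C(=O)NO)[C@H](c2ccccc2)C1`, with hydroxy in place of 4-carboxyphenyl on the amide-type nitrogen, gives 700 nM, so that a 3.1-fold lower number from compound 1 to compound 2 (0.50 log units; beyond the scatter). Compound 3 `CON(C)C(=O)[C@@H]1CC=C(CCC=C(C)C)C[C@H]1c1ccccc1` carries methoxy(methyl)amino in place of (4-carboxyphenyl)amino on the carbonyl carbon; for compound 3 this assay reports only a limit, > 23000 nM, and (the limit of > 23000 nM in this assay, at which 1 of the 3 values shown sits). Against compound 1 this is an at least 10-fold higher number from compound 1 to compound 3 (1.01 log units; beyond the scatter), against compound 2 an at least 32-fold higher number from compound 2 to compound 3 (1.51 log units; beyond the scatter).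

Compound 4 `CC(C)=CCCC1=CC[C@H](C(=O)Nc2ccc(C(=O)O)cc2)[C@@H](c2ccccc2)C1` differs from compound 1 only in configuration: the two compounds have the same atoms and bonds and differ only in configuration as drawn: 2 of 2 stereo elements differ (all stereocentres are inverted: mirror images); a stereocentre at a saturated ring carbon is drawn R in compound 1 and S in compound 4; a stereocentre at a saturated ring carbon is drawn R in compound 1 and S in compound 4. Among the compounds with values here, none of the measured steps touches configuration; all three change the group on the carbonyl carbon, so none bears directly on this step. Within the data shown here, with no mirror-image pair measured, the direction is open, and a change beyond the scatter either way is considered possible, so the estimate is set wide. Compound 4 is expected at 6000 nM, between 1500 nM and 23000 nM, which means a 2.7-fold higher number from compound 1 to compound 4 (0.44 log units; beyond the scatter) as the expected step.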

Compound 4, inhibition constant: > 23000 nM
Compound 4 was reported as a limit; the forecaster's own chance of this, stated with the estimate: 25%; at least 3.8-fold (0.58 log units) between middle value and limit.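

Inverting both stereocentres gives an at least 10-fold higher number from compound 1 to compound 4 (1.01 log units; beyond the scatter), the first step in the series that leaves the group on the carbonyl carbon unchanged, so configuration at these two saturated ring carbons matters in this assay. The loss can be assigned to configuration alone because no atom or bond changes: the fact that compounds 1 and 4 differ only in the configuration as drawn. Compound 4 gives > 23000 nM, which is a limit, and compound 3 sits at the same limit: the limit of > 23000 nM in this assay, at which 2 of the 4 values shown sit.

On these data alone, whether inverting only one of the two stereocentres is enough remains open, as does whether the hydroxy amide of compound 2 depends on configuration in the same way. As far as these compounds go, it is also open whether a tetrazole in place of the carboxylic acid of the 4-carboxyphenyl group would keep the preference for the configuration of compound 1.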